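Ester variants on the shared core: compound 4

The source may report more compounds than this note shows. Statements on the series, on what has been measured and on what is new or still open speak of the compounds shown alone.

Compound 1 `CCCCCCCCCCC[C@@H](C[C@@H]1OC(=O)[C@H]1CCCCCC)OC(=O)CNC(=O)OCc1ccccc1` gives > 25000 nM in an assay on COS-7 cells for inhibition of diacylglycerol lipase-alpha (Homo sapiens), read by scintillation counting (a higher number here means a weaker inhibitor, a lower number a stronger inhibitor), which is a limit of the assay and not a number, so only a limit is known for compound 1 (the limit of > 25000 nM in this assay, at which 1 of the 3 values shown sits). Compound 2 `CCCCCCCCCCC[C@@H](C[C@@H]1OC(=O)[C@H]1CCCCCC)OC(=O)CCNC=O` gives 600 nM in this assay, and compound 3 `CCCCCCCCCCC[C@@H](C[C@@H]1OC(=O)[C@H]1CCCCCC)OC(=O)[C@@H](NC(C)=O)C(C)C` gives 460 nM. The steps of an at least 41-fold lower number from compound 1 to compound 2 (1.61 log units; beyond the scatter) and an at least 54-fold lower number from compound 1 to compound 3 (1.73 log units; beyond the scatter) are both large, whereas the step of a 1.3-fold lower number from compound 2 to compound 3 (0.12 log units; within the scatter) stays within the scatter. Compound 4 `CCCCCCCCCCC[C@@H](C[C@@H]1OC(=O)[C@H]1CCCCCC)OC(=O)[C@@H](NC(C)=O)C(C)CC` differs from compound 1 by 1-acetamido-2-methylbutyl in place of ((benzyloxycarbonyl)amino)methyl on a carbonyl carbon. Compound 3, which carries a closely related acetamido ester, gives 460 nM, and that value guides the expectation here. The step of an at least 55-fold lower number from compound 1 to compound 4 (1.74 log units; beyond the scatter) is therefore expected to be large and downward. Compound 4 is estimated at 450 nM, with a range from 150 nM to 1400 nM.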

Compound 4, half-maximal inhibitory concentration: 430 nM
Compound 4: the middle estimate sits 1.0-fold (0.02 log units) above what was measured; low and high end bracket the measured number.
By their numbers in this assay, from the lowest: compounds 4, 3 and 2 (each within the scatter of the next). At a limit, above all of these: compound 1.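

Methyl in place of hydrogen on a saturated chain carbon gives a 1.1-fold lower number from compound 3 to compound 4 (0.03 log units; within the scatter) in this assay, and 1-acetamido-2-methylbutyl in place of 2-(formylamino)ethyl gives a 1.4-fold lower number from compound 2 to compound 4 (0.14 log units; within the scatter), so compounds 2, 3 and 4 cannot be told apart here. A third acylamino ester thus repeats the large step, an at least 58-fold lower number from compound 1 to compound 4 (1.76 log units; beyond the scatter). The size of that step remains open, since compound 1 gives a limit and not a number: the limit of > 25000 nM in this assay, at which 1 of the 4 values shown sits.

Which part of ((benzyloxycarbonyl)amino)methyl accounts for that step stays unresolved, since the groups differ in several features at once. Going by these compounds, how a free amine or a carboxylic acid would read on this carbonyl carbon also stays open.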